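A few compounds are considered here, and "the series" means these few. Any claim that something is new, unique, unknown or untested is made for them only; others in the source may bear on it.

Of the compounds shown here, three have been measured in an ADME assay for permeability, using PAMPA, in phosphate buffer, with a stated time of 4 h, tested at 1 mg/mL; a lower number here means that the compound crosses the layer more slowly, a higher number that the compound crosses the layer faster. Compound 1 `N#Cc1c(N)nc(NCCCC2CCN(Cc3ccccc3)CC2)c(C#N)c1-c1ccccc1` gives 31.6 10^-6 cm/s, compound 2 `N#Cc1cc(C#N)c(NCCC2CCN(Cc3ccccc3)CC2)nc1N` gives 14.4 10^-6 cm/s, and compound 3 `N#Cc1cc(C#N)c(NCCCCC2CCN(Cc3ccccc3)CC2)nc1N` gives 21.2 10^-6 cm/s. Compound 3 stands second highest of the three numbers; its nearest neighbour is compound 2, a gap that lies within the usual scatter, and its furthest is compound 1, again a gap within the scatter, so the three values cannot be told apart with confidence.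

Compound 4 `N#Cc1c(N)nc(NCCCCC2CCN(Cc3ccccc3)CC2)c(C#N)c1-c1ccccc1` has not yet been measured. Compared with compound 3, the change is phenyl in place of hydrogen on an aromatic carbon. Within the data shown here, no measured pair shows this exact change on its own, so the size of the step has to be guessed. The step from compound 3 to compound 4 in this assay is expected to be small, a 1.4-fold higher number from compound 3 to compound 4 (0.15 log units; within the scatter), most likely upward but possibly no larger than the scatter, given that compound 1, which also carries a phenyl, gives 31.6 10^-6 cm/s. Compound 4 is therefore estimated at 30 10^-6 cm/s, with a range from 18 10^-6 cm/s to 50 10^-6 cm/s.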

Compound 4, apparent permeability: 25.7 10^-6 cm/s
The estimate for compound 4 lay 1.2-fold (0.07 log units) above the measured number; measured number inside the range.
By their numbers in this assay, from the lowest: compounds 2, 3, 4 and 1 (each within the scatter of the next, the first and the last beyond it).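

In this assay, among these compounds, the first pair that isolates this change reads a 1.2-fold higher number from compound 3 to compound 4 (0.08 log units; within the scatter) for phenyl in place of hydrogen on an aromatic carbon, ortho to two cyano groups. A group of 6 heavy atoms can therefore stand at this position, and compound 3 and compound 4 still cannot be told apart in this read-out. Nothing in the data shown offers an explanation for this result.

At this position the compounds shown carry only hydrogen or phenyl, so how an amine, a carboxylic acid or a methyl group would read there remains open. Among the compounds shown here, whether the same step would hold with a different chain on the shared core is also open, since this is the only pair that shows it.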